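Cyano in place of methyl on selenium

The source may hold more compounds than are shown below. What is called first, only, known or untested is meant among the compounds shown, and "the series" means these compounds.

For the measured compounds named here, in a functional assay on LoVo cells (Homo sapiens) for inhibition, read by MTT assay, with a stated time of 48 h (on this read-out lower numbers stand for stronger inhibition and higher numbers for weaker inhibition), compound 1 `COc1ccc(N(C)c2nc(C)nc3ccccc23)cc1[Se]C` gives 3 nM, the lowest of the three numbers so far and beyond the scatter from both others. Compound 3 `Cc1nc(N(C)c2ccc([Se]C#N)c(Cl)c2)c2ccccc2n1` gives 12 nM, and compound 2 `Cc1nc(N(C)c2ccc(OCC[Se]C#N)cc2)c2ccccc2n1` gives 547 nM. Going by the values given here, both carry cyano on a selenium, but each also differs from compound 1 elsewhere, so no clean single-change step is available. Compound 4 `COc1ccc(N(C)c2nc(C)nc3ccccc23)cc1[Se]C#N` keeps the core of compound 1 and changes one group: cyano in place of methyl on a selenium. Compound 3, at 12 nM, is taken as the nearest guide among the measured compounds. The expected step is a 3.3-fold higher number from compound 1 to compound 4 (0.52 log units; beyond the scatter), towards weaker inhibition in this assay. Compound 4 is estimated at 10 nM, with an expected range of 3 nM to 40 nM.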

Compound 4, half-maximal inhibitory concentration: 73 nM
Compound 4: the middle estimate sits 7.3-fold (0.86 log units) below what was measured, and the stated range ends below it.
By their numbers in this assay, from the lowest: compound 1; then compound 3; then compound 4; then compound 2.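

For the compounds shown here, at this selenium, whose other neighbour is an aromatic carbon, cyano in place of methyl gives the first clean single-change step: in this assay, it is a 24-fold higher number from compound 1 to compound 4 (1.39 log units; beyond the scatter), towards weaker inhibition. The read-out is thus sensitive to the group on this selenium, and the shared core alone does not preserve the low number of compound 1. Nothing available accounts for the size of this step.

As far as these compounds go, whether ethyl or a longer alkyl chain on this selenium would keep the number close to that of compound 1 remains open. Also open, from the compounds shown here alone, is whether the exchange gives a similar step on a different core, such as that of compound 3.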